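Swapping a Trifluoromethyl for Chloro on a Sulfonamide Aryl Ring

The compounds below may be only part of what the source reports. "The series", "measured", "known", "first", "only" and "open" are said of these compounds alone.

Of the compounds shown here, two built on the same core have been measured so far. Compound 1, with the structure `CCOc1cc(=O)n(CCCO)c2c1CC(C/C=C(\C)CCC=C(C)C)C(C)(C)C2`, carries a short ether chain on the core. Compound 2, with the structure `CC(C)=CCC/C(C)=C/CC1Cc2c(OCCCNS(=O)(=O)c3ccc(C(F)(F)F)cc3)cc(=O)n(CCCO)c2CC1(C)C`, extends that chain into a sulfonamide bearing a 4-(trifluoromethyl)phenyl group. In a functional assay on PANC-1 cells (Homo sapiens) for inhibition, read by MTT assay, with a stated time of 24 h, tested at 10 uM (on this read-out higher numbers stand for more inhibition at the one concentration tested (going by the name of the read-out) and lower numbers for less inhibition), compound 1 gives 0.8%. In this assay compound 2 gives 0%. These two numbers lie within the usual scatter of each other, so neither compound shows any meaningful inhibition at the single concentration tested, and nothing can be said about a difference between them.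

Compound 3, with the structure `CC(C)=CCC/C(C)=C/CC1Cc2c(OCCCNS(=O)(=O)c3ccc(Cl)cc3)cc(=O)n(CCCO)c2CC1(C)C`, is the next compound to be measured. It differs from compound 2 in one place: chloro in place of trifluoromethyl on an aromatic carbon. Within the data shown here, no step between two measured compounds that differ in a single place is available, so there is no basis for expecting a change in this assay beyond the scatter in either direction. Since compound 2 gives 0%, compound 3 is expected to show about the same, with an estimated step of a number 2 percentage points higher from compound 2 to compound 3 (within the scatter). Compound 3 is therefore estimated at 2%, with a range from -8% to 12%.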

Compound 3, a percentage reported as inhibition, at one concentration (the size of the read-out at that concentration, not a potency): 16.1%
Compound 3: the middle estimate sits 14.1 percentage points below what was measured; measured number outside the range, above it.
By their numbers in this assay, from the lowest: compounds 2 and 1 (each within the scatter of the next); then compound 3.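

In this assay, among these compounds, chloro in place of trifluoromethyl on the aromatic carbon para to a large group gives a number 16.1 percentage points higher from compound 2 to compound 3 (beyond the scatter), the first change here that clears the scatter, so this position does affect the read-out even though the step is modest. Placing the (((4-chlorophenyl)sulfonyl)amino)methyl group on the saturated chain carbon gives a number 15.3 percentage points higher from compound 1 to compound 3 (beyond the scatter), which shows that this extended chain can go with a measurable read-out, but compound 2, which has the same chain ending in 4-(trifluoromethyl)phenyl, goes against any rule that the chain alone is enough. Nothing available explains why exchanging these two groups moves the number.

Two compounds at this position cannot show whether a methyl group, a methoxy group, a bromine atom or an amine on the same carbon would follow chloro or trifluoromethyl. Going by these compounds, it also remains open whether a longer chain between the core and the sulfonamide would change the picture, and whether the effect of chloro would hold at other concentrations.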